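The compounds below may be only part of what the source reports. "The series", "measured", "known", "first", "only" and "open" are said of these compounds alone.

Measured compounds:
Compound 1 `CC(C)c1ccc2ccc(=O)n(CCN(C)C)c2n1` gives 0.6 ug/mL in an assay on isolated protein (strain Charles River) for antagonist activity at histamine H2 receptor (Rattus norvegicus); on this read-out lower numbers stand for an effect already at smaller amounts and higher numbers for an effect only at larger amounts of compound.
Compound 2 `CNCCn1c(=O)ccc2c(C)cc(C)nc21` gives 21.1 ug/mL in this assay.

Compound 2 holds the highest number of the two. Its nearest neighbour, compound 1, sits at a far lower number, beyond the scatter; the two differ in more than one place, so only the two values themselves can be set side by side. Compound 3 `Cc1cc(C)c2ccc(=O)n(CCN(C(C)C)C(C)C)c2n1` awaits measurement in this assay. It differs from compound 2 by diisopropylamino in place of methylamino on a saturated chain carbon, two bonds along the chain from an aromatic nitrogen. Among the compounds with values here, no step between measured compounds touches this position, so the size of such a change cannot be read from the data. Compound 1, with a different side chain and a different substitution of the core, gives 0.6 ug/mL, which leaves room for compound 2's side chain to be part of its high number. A step toward a lower number is therefore expected for compound 3, of moderate size, a 5.3-fold lower number from compound 2 to compound 3 (0.72 log units; beyond the scatter). Compound 3 is expected at 4 ug/mL, within a range from 0.8 ug/mL to 15 ug/mL.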

Compound 3, half-maximal effective concentration: 1.44 ug/mL
Estimate against measurement, compound 3: 2.8-fold (0.44 log units) above; low and high end bracket the measured number.
By their numbers in this assay, from the lowest: compound 1; then compound 3; then compound 2.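

In this assay, putting diisopropylamino in place of methylamino on the saturated chain carbon gives a 15-fold lower number from compound 2 to compound 3 (1.17 log units; beyond the scatter), the first step read at this position, and it shows that the number responds strongly to the amine at the end of the chain on the shared core. The step combines two differences: the entering group has 7 heavy atoms against 2, and it has 0 hydrogen-bond donors against 1. Nothing given here separates these two differences or bears on why the number falls.

As far as these compounds go, it remains open whether dimethylamino, a primary amine or a ring amine such as piperidine on the same chain would give a number near that of compound 2 or that of compound 3. From the compounds shown here alone, the effect of a longer chain carrying diisopropylamino also remains open.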